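Ethyl to isopropyl amide on a thiophene-bearing core

The compounds below may be only part of what the source reports. "The series", "measured", "known", "first", "only" and "open" are said of these compounds alone.

Measured so far:
Compound 1 `CCNC(=O)C1=C(C)NC(=O)NC1c1ccco1`: 2%
Compound 2 `CC1=C(C(=O)NC(C)C)C(c2ccco2)NC(=O)N1`: 3%
Compound 3 `CCNC(=O)C1=C(C)NC(=O)NC1c1cccs1`: 1%

In an assay on membranes from CHO cells for displacement of a labelled ligand from adenosine receptor A1 (Homo sapiens), read by scintillation counting, with a stated time of 60 min, tested at 1 uM (a higher number here means more inhibition at the concentration tested (going by the name of the read-out), a lower number less inhibition), compound 1 gives 2% and compound 2 gives 3%; the change between them is methyl in place of hydrogen on a saturated chain carbon bound to an amide-type nitrogen and a saturated chain carbon and the step is a number 1 percentage points higher from compound 1 to compound 2 (within the scatter). Compound 3, which in this assay gives 1%, differs from compound 1 by thiophen-2-yl in place of furan-2-yl on a saturated ring carbon, with the step of a number 1 percentage points lower from compound 1 to compound 3 (within the scatter). Compound 4 `CC1=C(C(=O)NC(C)C)C(c2cccs2)NC(=O)N1` is not yet measured; it differs from compound 3 by methyl in place of hydrogen on a saturated chain carbon bound to an amide-type nitrogen and a saturated chain carbon, the same change as from compound 1 to compound 2, made on the other core. Because the earlier step was a number 1 percentage points higher from compound 1 to compound 2 (within the scatter) and all three numbers lie close together, compound 4 is expected to show a step of about a number 1 percentage points higher from compound 3 to compound 4 (within the scatter), within the scatter. The estimate for compound 4 in this assay is 2%, between -5% and 9%.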

Compound 4, a percentage reported as inhibition, at one concentration (the size of the read-out at that concentration, not a potency): 2%
Compound 4: the middle estimate sits on the measured number at the digits printed, and the stated range covers the measured number.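

In this assay, the step for ethylcarbamoyl to isopropylcarbamoyl on the thiophen-2-yl compounds is a number 1 percentage points higher from compound 3 to compound 4 (within the scatter), and it agrees with the step on the furan-2-yl compounds: the same change on two cores in this assay, a number 1 percentage points higher (within the scatter) from compound 1 to compound 2 and a number 1 percentage points higher (within the scatter) from compound 3 to compound 4, 0 percentage points apart, within the scatter of two such steps. The step for furan-2-yl to thiophen-2-yl on the isopropylcarbamoyl compounds is a number 1 percentage points lower from compound 2 to compound 4 (within the scatter), and it agrees in the same way with the step on the ethylcarbamoyl compounds: the same change on two cores in this assay, a number 1 percentage points lower (within the scatter) from compound 1 to compound 3 and a number 1 percentage points lower (within the scatter) from compound 2 to compound 4, 0 percentage points apart, within the scatter of two such steps. This shows that neither change moved the read-out beyond the scatter on either core, but it does not show that a change with a real effect would carry over from one core to another.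

The compounds shown leave open whether a benzyl group on the amide nitrogen, or a phenyl ring in place of the furan-2-yl or thiophen-2-yl, would give a read-out clear of the scatter. They also leave open the potency of any of these compounds, as each value is a read-out at one concentration.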